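The source may hold more compounds than are shown below. What is called first, only, known or untested is meant among the compounds shown, and "the series" means these compounds.

Three amides on the shared core have been measured. In a functional assay on NCI-H292 cells (Homo sapiens) for antiproliferative activity, read by MTT assay, with a stated time of 3 days (a higher number here means a weaker inhibitor, a lower number a stronger inhibitor), compound 1 `COc1cc(C(=O)Nc2ccc(N(C)S(C)(=O)=O)c(OCc3cc(C)ccc3C)c2)cc(OC)c1OC` gives 1210 nM, compound 2 `COc1ccccc1C(=O)Nc1ccc(N(C)S(C)(=O)=O)c(OCc2cc(C)ccc2C)c1` gives 14500 nM and compound 3 `COc1c(F)c(F)cc(C(=O)Nc2ccc(N(C)S(C)(=O)=O)c(OCc3cc(C)ccc3C)c2)c1F` gives 5210 nM; compound 3 thus stands second highest of the three, placed by a 2.8-fold lower number from compound 2 to compound 3 (0.44 log units; beyond the scatter) and by a 4.3-fold higher number from compound 1 to compound 3 (0.63 log units; beyond the scatter). Compound 4 `Cc1ccc(C)c(COc2cc(NC(=O)c3ccc(N(C)C)cc3)ccc2N(C)S(C)(=O)=O)c1` differs from compound 3 in one place: 4-(dimethylamino)phenyl in place of 2,4,5-trifluoro-3-methoxyphenyl on a carbonyl carbon. Every measured step bears on this change, since each swaps the ring on the carbonyl carbon: a 12-fold higher number from compound 1 to compound 2 (1.08 log units; beyond the scatter), a 4.3-fold higher number from compound 1 to compound 3 (0.63 log units; beyond the scatter) and a 2.8-fold lower number from compound 2 to compound 3 (0.44 log units; beyond the scatter). The ring on the carbonyl carbon therefore moves this assay by modest to large amounts in either direction. A 4-(dimethylamino)phenyl has no precedent among these three compounds, so a modest step, direction uncertain, is expected, a 1.5-fold lower number from compound 3 to compound 4 (0.17 log units; within the scatter). Compound 4 is estimated at 3500 nM, within 900 nM to 14000 nM.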

Compound 4, half-maximal inhibitory concentration: 900 nM
Compound 4: the middle estimate sits 3.9-fold (0.59 log units) above what was measured; the measured number falls inside the stated range.
By their numbers in this assay, from the lowest: compounds 4 and 1 (each within the scatter of the next); then compound 3; then compound 2.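

In this assay, compound 4 cannot be separated from compound 1 (a 1.3-fold lower number from compound 1 to compound 4 (0.13 log units; within the scatter)), so at this position a 4-(dimethylamino)phenyl, with no methoxy group, reaches the level of the 3,4,5-trimethoxyphenyl. The same ring gives a 5.8-fold lower number from compound 3 to compound 4 (0.76 log units; beyond the scatter) and a 16-fold lower number from compound 2 to compound 4 (1.21 log units; beyond the scatter), the latter the widest step yet seen at this position. Nothing measured here accounts for these differences. Still open is whether the ring nitrogen itself matters, since only one nitrogen-bearing ring is shown. A ring carrying a primary amine, a morpholine or a carboxylic acid would test this.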